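Cytotoxicity notes: amide substituent change, compound 2 to compound 3

The compounds below may be only part of what the source reports. "The series", "measured", "known", "first", "only" and "open" are said of these compounds alone.

Measured so far:
compound 1 `O=C(Cn1c(=O)oc2cc([N+](=O)[O-])ccc21)Nc1ccccn1` — 47.3%
compound 2 `O=C(Cn1c(=O)oc2cc(Cl)ccc21)NCc1cccs1` — 53.6%

In an ADME assay on RAW264.7 cells (Mus musculus) for cytotoxicity, read by MTT assay, with a stated time of 72 h, tested at 100 uM (on this read-out lower numbers stand for a weaker effect and higher numbers for a stronger effect at the one concentration tested), compound 1 gives 47.3% and compound 2 gives 53.6%. Compound 2 holds the higher of the two numbers, yet the gap to compound 1 lies within the scatter, so no order between them is claimed. Compound 3 `O=C(Cn1c(=O)oc2cc(Cl)ccc21)Nc1ccccc1` is not yet measured. Its difference from compound 2 is phenyl in place of (thiophen-2-yl)methyl on an amide-type nitrogen. Among the measured compounds shown here, no pair of measured compounds isolates this change, so the data give no direction for it. Compound 3 is expected to give 48% in this assay, within 30% to 66%. The implied step, a number 5.6 percentage points lower from compound 2 to compound 3 (within the scatter), is expected to stay within the scatter.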

Compound 3, a percentage reported as inhibition, at one concentration (the size of the read-out at that concentration, not a potency): 20.2%
Estimate against measurement, compound 3: 27.8 percentage points above; the measured number lies below the stated range.
By their numbers in this assay, from the lowest: compound 3; then compounds 1 and 2 (each within the scatter of the next).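

In this assay, phenyl in place of (thiophen-2-yl)methyl on the amide-type nitrogen gives a number 33.4 percentage points lower from compound 2 to compound 3 (beyond the scatter), so this position can strongly alter the read-out, which the earlier comparison of compound 1 and compound 2 could not show. This rests on a single pair, and nothing available bears on the cause of the step.

Going by these compounds, the change replaces the ring and removes the link to it in one move, so their separate contributions remain open. Where benzyl or a longer chain ending in an amine would fall on this read-out also remains open.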